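Taking one methoxy from compound 2

The compounds below may be only part of what the source reports. "The series", "measured", "known", "first", "only" and "open" are said of these compounds alone.

In a functional assay on HeLa cells (Homo sapiens) for antiproliferative activity, read by cell counting, with a stated time of 2 days (a higher number here means a weaker inhibitor, a lower number a stronger inhibitor), compound 2 `COc1cc(C(=O)c2sc(N3CCCC3)nc2N)cc(OC)c1OC` gives 340 nM. For the measured compounds named here, compound 1 `CCCCN(C)c1nc(N)c(C(=O)c2cc(OC)c(OC)c(OC)c2)s1` gives 31000 nM, which leaves compound 2 with the lower number, and so the stronger inhibition, of the two measured so far. Compound 3 `COc1ccc(C(=O)c2sc(N3CCCC3)nc2N)cc1OC` keeps the pyrrolidin-1-yl group of compound 2 and changes another part of the molecule: hydrogen in place of methoxy on an aromatic carbon. This puts hydrogen in place of methoxy on an aromatic carbon of a six-membered aromatic ring of carbon only, ortho to a methoxy group.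

Going by the values given here, only one measured step exists, and it has pyrrolidin-1-yl in place of butyl(methyl)amino on an aromatic carbon: a 91-fold lower number from compound 1 to compound 2 (1.96 log units; beyond the scatter). That step lies at another place on the molecule, so it sets no direction for this change. Among the compounds with values here, it shows only that a single change in these compounds can move the number widely. Within the data shown here, no measured step involves a methoxy group, so the direction is a judgement. A sizeable step towards a higher number, meaning weaker inhibition, is expected in this assay. The expected step is a 12-fold higher number from compound 2 to compound 3 (1.07 log units; beyond the scatter). For compound 3 the estimated value is 4000 nM, with an expected range of 700 nM to 25000 nM.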

Compound 3, half-maximal inhibitory concentration: 36000 nM
Compound 3: middle estimate off by 9.0-fold (0.95 log units), on the low side; measured number outside the range, above it.
By their numbers in this assay, from the lowest: compound 2; then compounds 1 and 3 (each within the scatter of the next).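

In this assay, taking away a single methoxy group, the one ortho to a methoxy group and meta to a large group, gives a 110-fold higher number from compound 2 to compound 3 (2.02 log units; beyond the scatter). For the compounds shown here, until now, the only large step came from the other end of the molecule, where swapping butyl(methyl)amino for pyrrolidin-1-yl gave a 91-fold lower number from compound 1 to compound 2 (1.96 log units; beyond the scatter); this new step shows that the six-membered aromatic ring of carbon only also matters, and that losing just 2 heavy atoms from it can cost a large part of the inhibition seen with compound 2. Nothing measured here explains why this methoxy group counts for so much.

Hydrogen is the only replacement shown at this carbon, so it remains open whether the methoxy group itself is needed or whether a hydroxyl group, a chlorine atom or an ethoxy group could stand in for it and keep the number low. Going by these compounds, it is also open whether removing this methoxy group would have a step of similar size on a compound carrying butyl(methyl)amino instead of pyrrolidin-1-yl, as the two changes are seen here only one at a time.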